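This account rests on a few compounds, and the source may have more. Where it says the series, first, only, none or still open, it means among the compounds named here.

Measured in a functional assay on MCF7 cells (Homo sapiens) for cytotoxicity, read by MTT assay, with a stated time of 72 h (a lower number here means a stronger inhibitor, a higher number a weaker inhibitor), are these compounds:
Compound 1 `COc1ccc(/C=C2\CCC/C(=C\c3cccc(Cl)c3)C2=O)cc1OC` gives 6000 nM
Compound 2 `COc1ccc(/C=C2\CCC/C(=C\c3cccc(Br)c3)C2=O)cc1OC` gives 5300 nM
Compound 3 `COc1ccc(/C=C2\CCC/C(=C\c3cccc(Cl)c3Cl)C2=O)cc1OC` gives 14300 nM

Compound 3 has the highest number of the three and is the weakest inhibitor in this small set. The measured steps leading to it are a 2.4-fold higher number from compound 1 to compound 3 (0.38 log units; beyond the scatter) and a 2.7-fold higher number from compound 2 to compound 3 (0.43 log units; beyond the scatter) and both are modest. The remaining step, a 1.1-fold lower number from compound 1 to compound 2 (0.05 log units; within the scatter) and so gives no order between those two compounds.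

The unmeasured compound 4 `COc1ccc(/C=C2\CCC/C(=C\c3ccc(Cl)cc3Cl)C2=O)cc1OC` keeps the shared core and carries 2,4-dichlorophenyl in place of 2,3-dichlorophenyl on a double-bonded chain carbon bound to a double-bonded ring carbon. The change is 2,4-dichlorophenyl in place of 2,3-dichlorophenyl on a double-bonded chain carbon bound to a double-bonded ring carbon and the two compounds have the same atoms, joined differently. Among the compounds with values here, no measured step moves a chloro group in this way, so the evidence is indirect. The closest guide is the addition of a second chloro group, seen in a 2.4-fold higher number from compound 1 to compound 3 (0.38 log units; beyond the scatter) and only in that one case. Compound 4 also holds two chloro groups, so its number is expected to stay near that of compound 3 at 14300 nM and no step beyond the scatter is expected. The expected step is a 1.3-fold lower number from compound 3 to compound 4 (0.11 log units; within the scatter) and it carries little confidence. For compound 4 the estimated value is 11000 nM with an expected range from 4500 nM to 24000 nM in this assay when measured.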

Compound 4, half-maximal inhibitory concentration: 16200 nM
The estimate for compound 4 lay 1.5-fold (0.17 log units) below the measured number, within the range that was stated.
By their numbers in this assay, from the lowest: compounds 2 and 1 (each within the scatter of the next); then compounds 3 and 4 (each within the scatter of the next).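

In this assay, replacing 2,3-dichlorophenyl with 2,4-dichlorophenyl on a double-bonded chain carbon bound to a double-bonded ring carbon gives a 1.1-fold higher number from compound 3 to compound 4 (0.05 log units; within the scatter), so this rearrangement of the same atoms puts compound 3 and compound 4 in no order. The higher number seen with compound 3 is therefore not confined to the 2,3-dichlorophenyl group: the 2,4-dichlorophenyl group also stands apart from the singly halogenated groups, with a 2.7-fold higher number from compound 1 to compound 4 (0.43 log units; beyond the scatter) and a 3.1-fold higher number from compound 2 to compound 4 (0.49 log units; beyond the scatter), and none of the four compounds goes against this pattern. Nothing shown here accounts for these steps.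

The compounds shown cover only chloro and bromo groups on the phenyl ring at this place, and only the 3-substituted, 2,3-disubstituted and 2,4-disubstituted arrangements, so they leave open how a 3,4-dichlorophenyl or 3,5-dichlorophenyl group would compare with these two dichlorophenyl groups. They also leave open whether a phenyl ring carrying a methoxy group, an amine or a carboxylic acid at this place would follow the same pattern in this assay.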